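This account rests on a few compounds, and the source may have more. Where it says the series, first, only, none or still open, it means among the compounds named here.

Compound 2 `CC(C(=O)N1CCCCC1)N1CCN(S(=O)(=O)c2ccc(C(C)(C)C)cc2)CC1` is one of two compounds examined in an ADME assay on HepG2 cells (Homo sapiens) for inhibition, with a stated time of 48 h (a lower number here means that less compound is needed, a higher number that more compound is needed for the effect), and for it the assay returns only a limit. In this assay compound 2 gives > 40000 nM, which is a limit of the assay and not a number. Its companion, compound 1 `CC(C(=O)N1CC2CC2C1)N1CCN(S(=O)(=O)c2ccc(C(C)(C)C)cc2)CC1`, differs from it on the carbonyl carbon. In this assay compound 1 gives > 40000 nM, likewise a limit. Going by the values given here, the step that the two limits leave unreadable from compound 1 to compound 2 is therefore unreadable, and the only evidence on the numbers is the limit of > 40000 nM in this assay, at which 2 of the 2 values shown sit.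

Compound 3 `CC1CCN(C(=O)C(C)N2CCN(S(=O)(=O)c3ccc(C(C)(C)C)cc3)CC2)CC1` is the next compound in this series and has not yet been measured. Its difference from compound 2 is methyl in place of hydrogen on a saturated ring carbon, in words methyl in place of hydrogen on a saturated ring carbon. Among the compounds with values here, no measured step bears on this change, and the one step that was measured could not be sized. The expected step from compound 2 to compound 3 is a step that the limit leaves unreadable from compound 2 to compound 3, that is, none that could be read. Compound 3 is therefore estimated at 60000 nM, with a range from 20000 nM to 200000 nM, most likely reported again as a limit.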

Compound 3, half-maximal effective concentration: > 40000 nM
Compound 3: no number, only a limit; the forecaster's own chance of this, stated with the estimate: 75%; the middle value is on the limit's open side.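

In this assay compound 3 gives > 40000 nM, which is a limit and not a number. Going by these compounds alone, no step among compound 1, compound 2 and compound 3 can be read, and the evidence stays as it was: the limit of > 40000 nM in this assay, at which 3 of the 3 values shown sit. The compounds shown leave open how large any of these values is and whether 4-methylpiperidin-1-yl and piperidin-1-yl differ at all in this assay.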